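The source may hold more compounds than are shown below. What is called first, only, known or untested is meant among the compounds shown, and "the series" means these compounds.

Three compounds that share one core set the scene in a functional assay on L6 cells (Rattus norvegicus) for inhibition; a higher number here means a weaker inhibitor, a lower number a stronger inhibitor. In this test, compound 1 `CC(C)c1c(C(=O)N(C)Cc2ccccc2)nn(-c2ccc(F)cc2)c1OC[C@@H](O)C[C@@H](O)CC(=O)O` gives 6720 nM, and compound 2 `CC(C)c1c(C(=O)N2CCC[C@H](c3ccccc3)C2)nn(-c2ccc(F)cc2)c1OC[C@@H](O)C[C@@H](O)CC(=O)O` gives 1110 nM. Among the measured compounds shown here, the only measured step, a 6.1-fold lower number from compound 1 to compound 2 (0.78 log units; beyond the scatter), replaces the whole group on the carbonyl carbon, so it shows that this part of the molecule can shift the read-out. Compound 3 `COc1ccc(CNC(=O)c2nn(-c3ccc(F)cc3)c(OC[C@@H](O)C[C@@H](O)CC(=O)O)c2C(C)C)cc1` offers no such anchor, as its entry in this assay reads "not determined" (no result reported). It therefore has no place on the scale, and nothing can be said about whether it is stronger or weaker than its relatives.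

The next compound, compound 4 `COc1cccc(CNC(=O)c2nn(-c3ccc(F)cc3)c(OC[C@@H](O)C[C@@H](O)CC(=O)O)c2C(C)C)c1`, is built from compound 3 by a small change: 3-methoxyphenyl in place of 4-methoxyphenyl on a saturated chain carbon bound to an amide-type nitrogen. The methoxy group stays on the ring, and 3-methoxyphenyl simply stands in place of 4-methoxyphenyl. For the measured compounds named here, no measured step covers a change of this kind, and with no starting number, neither a size nor a direction can be expected for it. The estimate must instead lean on the nearest measured relative, compound 1 at 6720 nM, which also has a benzyl group on the amide-type nitrogen. For compound 4, the expected value in this assay is 4000 nM, with an estimated range from 800 nM to 20000 nM.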

Compound 4, half-maximal inhibitory concentration: 8750 nM
Beside the measured number, compound 4's estimate is 2.2-fold (0.34 log units) below it, and the stated range covers the measured number.
By their numbers in this assay, from the lowest: compound 2; then compounds 1 and 4 (each within the scatter of the next).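

In this assay, the move of the methoxy group from 4-methoxyphenyl to 3-methoxyphenyl cannot be read as a step, as compound 3 has no number to start from. What compound 4 adds is a second benzyl-type amide with a number: a 1.3-fold higher number from compound 1 to compound 4 (0.11 log units; within the scatter) lies within the scatter, so (3-methoxybenzyl)amino and benzyl(methyl)amino on the carbonyl carbon cannot be told apart here, whereas a 7.9-fold higher number from compound 2 to compound 4 (0.90 log units; beyond the scatter) lies beyond it, and among the three compounds with numbers, compound 2 with its 3-phenylpiperidin-1-yl group is the strongest inhibitor. No measurement among these data offers an explanation for these differences.

The compounds shown leave open how much of the gain in compound 2 belongs to the phenyl group on the piperidine ring, a question that a plain piperidin-1-yl group on the carbonyl carbon would address. They also leave open whether the methoxy group on the benzyl ring matters at all, which a simple benzylamino group or a 3-hydroxybenzyl group in the same place could help to settle.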